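This account rests on a few compounds, and the source may have more. Where it says the series, first, only, none or still open, it means among the compounds named here.

Measured in a functional assay on L1210 cells (Mus musculus) for inhibition; on this read-out higher numbers stand for weaker inhibition and lower numbers for stronger inhibition:
- compound 1 `Nc1ncnc2c1ncn2C/C=C/CCl`: 45000 nM
- compound 2 `Nc1ccn(C/C=C\CCl)c(=O)n1`: 10000 nM

Compound 1 carries the higher number of the two, which means the weaker inhibition, and its gap to compound 2 lies beyond the scatter. Compound 3 `Nc1ncnc2c1ncn2C=C=CCCl` has not yet been measured. It keeps the core of compound 1 and alters only the chain on the aromatic nitrogen: 4-chlorobuta-1,2-dien-1-yl in place of 4-chlorobut-2-en-1-yl on an aromatic nitrogen. In words, 4-chlorobuta-1,2-dien-1-yl stands in place of 4-chlorobut-2-en-1-yl. Going by the values given here, no measured pair differs in one place only, so the data offer no direct guide to this change. In this assay a small step towards stronger inhibition is expected, one not beyond the scatter. The expected change is a 1.8-fold lower number from compound 1 to compound 3 (0.26 log units; within the scatter). The estimate for compound 3 is 25000 nM, with an expected range of 7000 nM to 80000 nM.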

Compound 3, half-maximal inhibitory concentration: 45000 nM
For compound 3 the middle estimate is 1.8-fold (0.26 log units) below the measured one; the measured number falls inside the stated range.
By their numbers in this assay, from the lowest: compound 2; then compounds 1 and 3 (each within the scatter of the next).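

In this assay, going by these compounds alone, putting 4-chlorobuta-1,2-dien-1-yl in place of 4-chlorobut-2-en-1-yl on the aromatic nitrogen gives no change at the digits printed from compound 1 to compound 3 (within the scatter), the first comparison that differs in one place only. On the core of compound 1, the chain at this position can thus carry a second double bond outside the aromatic rings, at the same count of heavy atoms, with no shift in the read-out beyond the scatter. No measured property is available to explain this result.

Open, on these data alone, is whether the chlorine of the chain matters at all, which a bromine or a hydroxyl in its place, or a longer chain on the same nitrogen, would address. Also open, as far as these compounds go, is whether the same exchange on the core of compound 2 would give a similarly flat step.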